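A few compounds are considered here, and "the series" means these few. Any claim that something is new, unique, unknown or untested is made for them only; others in the source may bear on it.

Notes on the series. In a functional assay on the whole organism (spleen, spleen) with Rattus norvegicus as the target (on this read-out higher numbers stand for an effect only at larger amounts of compound and lower numbers for an effect already at smaller amounts), compound 1 `CCCCCCCOc1ccc(CCC(N)(CO)CCC)cc1` gives 3.1 mg/kg, and compound 2 `CCCCCCCOc1ccc(CCC(N)(CO)CCO)cc1` gives 0.038 mg/kg, the lowest of the two numbers measured; the step of an 82-fold lower number from compound 1 to compound 2 (1.91 log units; beyond the scatter) is the only one recorded. Compound 3 `CCCCCCCOc1ccc(CC[C@@](N)(CO)CCO)cc1` differs from compound 2 in this way: the two compounds have the same atoms and bonds; at least one stereo element is drawn with a configuration in one of them and without one in the other: 1 of 1 stereo elements differ; a stereocentre at a saturated chain carbon is drawn without a configuration in compound 2 and S in compound 3. Among the compounds with values here, no measured step bears on such a change: the only recorded step, from compound 1 to compound 2, alters a substituent, not a configuration, so it gives no guide here. Compound 2 is drawn without configuration and may contain both configurations; compound 3 is one of them. Its number in this assay may therefore lie close to that of compound 2, or somewhat lower, or markedly higher if the other configuration carries the effect. On that basis compound 3 is expected to give about 0.03 mg/kg, within the range 0.008 mg/kg to 0.4 mg/kg. The expected step is a 1.3-fold lower number from compound 2 to compound 3 (0.10 log units; within the scatter).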

Compound 3, dose for 50% inhibition: 0.017 mg/kg
The estimate for compound 3 lay 1.8-fold (0.25 log units) above the measured number; measured number inside the range.
By their numbers in this assay, from the lowest: compound 3; then compound 2; then compound 1.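

In this assay, drawing the saturated chain carbon as S gives a 2.2-fold lower number from compound 2 to compound 3 (0.35 log units; beyond the scatter), the first sign in the series that configuration at this carbon affects the number; the earlier pair differed only in a substituent and could not show this. The step is modest and does not compare two defined configurations, so the size of any gap between S and R cannot be read from it: the fact that one of compounds 2 and 3 is drawn with a defined configuration and the other without, at the place where they differ. With the hydroxy on the chain and the S configuration together, the change is a 180-fold lower number from compound 1 to compound 3 (2.26 log units; beyond the scatter), the largest step recorded so far.

From the compounds shown here alone, how the R configuration at this carbon would read remains open. Also open, going by these compounds, is whether an amine or a carboxylic acid in place of the chain hydroxy would keep a number this low.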